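A few compounds are considered here, and "the series" means these few. Any claim that something is new, unique, unknown or untested is made for them only; others in the source may bear on it.

The measured compounds:
compound 1, `O=C(Nc1cccc(-n2cc(-c3ccncc3)c(-c3cc(O)cc(Cl)c3)n2)c1)Nc1ccc(Cl)c(C(F)(F)F)c1`, which in a functional assay on SNB-19 cells (Homo sapiens) for inhibition, read by sulforhodamine B assay, with a stated time of 48 h, tested at 1 uM (on this read-out lower numbers stand for a stronger effect and higher numbers for a weaker effect at the one concentration tested), gives 104%
compound 2, `O=C(Nc1cccc(-n2cc(-c3ccncc3)c(-c3cc(O)cc(Cl)c3)n2)c1)Nc1ccc(Cl)c(Cl)c1`, which in this assay gives 90%
compound 3, `COc1cc(Cl)cc(-c2nn(-c3cccc(NC(=O)Nc4cc(C(F)(F)F)cc(C(F)(F)F)c4)c3)cc2-c2ccncc2)c1`, which in this assay gives 28%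

Compound 3 stands lowest of the three numbers, which on this read-out means the strongest effect at the concentration tested. Compound 2 lies nearest to it and compound 1 furthest, and both gaps are beyond the usual scatter, so compound 3 is clearly set apart from the other two.

Compound 4, `COc1cc(Cl)cc(-c2nn(-c3cccc(NC(=O)Nc4cccc(C(F)(F)F)c4)c3)cc2-c2ccncc2)c1`, has not yet been measured. It differs from compound 3 by hydrogen in place of trifluoromethyl on an aromatic carbon. Among the measured compounds shown here, the only measured step that touches a trifluoromethyl group is a number 14 percentage points lower from compound 1 to compound 2 (beyond the scatter), and that step moved toward a stronger effect. It swapped the group for chloro rather than for hydrogen, however, and it was made on compounds with a different core, so it bears on the present change only loosely. For the measured compounds named here, with no closer precedent, the loss of one trifluoromethyl group from the strongest compound is expected to weaken the effect moderately. The step expected is a number 22 percentage points higher from compound 3 to compound 4 (beyond the scatter), and compound 4 is estimated to give 50%, with a range from 25% to 85%.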

Compound 4, a percentage reported as activity, at one concentration (the size of the read-out at that concentration, not a potency): 77%
The estimate for compound 4 lay 27 percentage points below the measured number; the measured number falls inside the stated range.
By their numbers in this assay, from the lowest: compound 3; then compound 4; then compound 2; then compound 1.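

In this assay, putting hydrogen in place of trifluoromethyl on this six-membered aromatic ring of carbon only gives a number 49 percentage points higher from compound 3 to compound 4 (beyond the scatter). In this pair, then, the trifluoromethyl group that leaves, meta to the trifluoromethyl group that stays, matters greatly to the effect seen at the one concentration tested, and a single substitution is enough to lose much of it. The data offer no measurement that explains why this change has so large an effect.

The earlier step, a number 14 percentage points lower from compound 1 to compound 2 (beyond the scatter), exchanged a trifluoromethyl group for chloro on a different core, so it cannot say whether the large change here would also appear on the core of compound 1. Going by these compounds, it also remains open whether this position needs trifluoromethyl specifically or would accept another group, such as a methyl group, an amine or a carboxylic acid, and whether any of these would hold the effect of compound 3 at 28%.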